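A few compounds are considered here, and "the series" means these few. Any claim that something is new, unique, unknown or untested is made for them only; others in the source may bear on it.

Measured so far in a functional assay on A549 cells (Homo sapiens) for antiproliferative activity, read by MTT assay, with a stated time of 48 h; on this read-out lower numbers stand for stronger inhibition and higher numbers for weaker inhibition:
compound 1 `N#CC1=C(N)Oc2c(N)cc3nc4ccccc4nc3c2C12C(=O)N(Cc1cnnn1-c1ccc(F)cc1)c1ccccc12` gives > 50000 nM, a limit of the assay.
compound 2 `N#CC1=C(N)Oc2c(N)cc3nc4ccccc4nc3c2C12C(=O)N(Cc1cnnn1-c1cccc(C(F)(F)F)c1)c1ccccc12` gives 5400 nM.
compound 3 `CCOc1ccccc1-n1nncc1CN1C(=O)C2(C(C#N)=C(N)Oc3c(N)cc4nc5ccccc5nc4c32)c2ccccc21` gives > 50000 nM, a limit of the assay.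

Compound 3 therefore stands at the assay limit, not at a number, and it shares that position with compound 1 (the limit of > 50000 nM in this assay, at which 2 of the 3 values shown sit). Only compound 2 carries a number, and the step of an at least 9.2-fold higher number from compound 2 to compound 3 (0.96 log units; beyond the scatter) is at least modest, while the step that the two limits leave unreadable from compound 1 to compound 3 cannot be read from two limits. Compound 4 `Cc1ccc(C)c(-n2nncc2CN2C(=O)C3(C(C#N)=C(N)Oc4c(N)cc5nc6ccccc6nc5c43)c3ccccc32)c1` differs from compound 3 in one place: 2,5-dimethylphenyl in place of 2-ethoxyphenyl on an aromatic nitrogen. Within the data shown here, neither measured step exchanges the 2-ethoxyphenyl for another aryl, so the change has no direct precedent; the only point of reference is that the three aryl groups tried so far give two limits and one number. The step of an at least 1.2-fold lower number from compound 3 to compound 4 (0.09 log units; that floor lies within the scatter) is expected to be small, with the chance of a number rather than a limit kept open. Compound 4 is estimated at 40000 nM, within 8000 nM to 120000 nM.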

Compound 4, half-maximal inhibitory concentration: > 50000 nM
Compound 4: no number, only a limit (the forecaster's own chance of this, stated with the estimate: 60%); middle value at least 1.2-fold (0.09 log units) away from the limit.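

In this assay, 2,5-dimethylphenyl in place of 2-ethoxyphenyl on the aromatic nitrogen still gives a limit and no number, so removing the oxygen of the ethoxy group while keeping a substituted phenyl ring does not bring this position into measurable range. Among these compounds, the 3-(trifluoromethyl)phenyl group remains the only aryl group here with a number, and the step to the new group is an at least 9.2-fold higher number from compound 2 to compound 4 (0.96 log units; beyond the scatter). Steps between two limits cannot be read, and the limit now holds most of the set: the limit of > 50000 nM in this assay, at which 3 of the 4 values shown sit.

As far as these compounds go, whether the number of compound 2 comes from the trifluoromethyl group itself or from where it sits on the phenyl ring stays open. Also open, from the compounds shown here alone, is whether a phenyl ring bearing a chlorine, an amine or a carboxylic acid on this nitrogen would give a number.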